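Trimming a sulfonyl substituent in a cytotoxicity screen

The source may hold more compounds than are shown below. What is called first, only, known or untested is meant among the compounds shown, and "the series" means these compounds.

Of the compounds shown here, three with a shared core have been tested in an ADME assay on MT4 cells (Homo sapiens) for cytotoxicity, read by MTT assay; on this read-out higher numbers stand for lower toxicity in this test and lower numbers for higher toxicity in this test. Compound 1 `Cc1cc(/C=C/C#N)cc(C)c1Oc1ccnc(Nc2ccc(CN3CCCN(S(=O)(=O)C(C)C)CC3)cc2)n1` gives 4640 nM. Compound 2 `Cc1cc(/C=C/C#N)cc(C)c1Oc1ccnc(Nc2ccc(CN3CCN(S(=O)(=O)N(C)C)CC3)cc2)n1` gives 3070 nM, and compound 3 `C=CC(=O)N1CCN(Cc2ccc(Nc3nccc(Oc4c(C)cc(C#N)cc4C)n3)cc2)CC1` gives 7580 nM. All three numbers sit within the usual scatter of one another, so the measurements cannot separate them. Compound 4 `Cc1cc(/C=C/C#N)cc(C)c1Oc1ccnc(Nc2ccc(CN3CCCN(S(C)(=O)=O)CC3)cc2)n1` has not yet been tested in this assay. It differs from compound 1 by methyl in place of isopropyl on a sulfonyl sulfur. Within the data shown here, no measured pair shows what this change does here, so no direction can be claimed from the data. Compound 4 is therefore expected to give about 4500 nM, with a range from 2000 nM to 10000 nM. The estimated step of a 1.0-fold lower number from compound 1 to compound 4 (0.01 log units; within the scatter) is expected to stay within the scatter.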

Compound 4, half-maximal cytotoxic concentration: 17400 nM
The estimate for compound 4 lay 3.9-fold (0.59 log units) below the measured number, and the stated range ends below it.
By their numbers in this assay, from the lowest: compounds 2, 1 and 3 (each within the scatter of the next, the first and the last beyond it); then compound 4.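

In this assay the group on the sulfonyl sulfur turns out to matter: methyl in place of isopropyl gives a 3.8-fold higher number from compound 1 to compound 4 (0.57 log units; beyond the scatter) and so points to lower toxicity in this test. The wider swap of 4-(dimethylsulfamoyl)piperazin-1-yl for 4-(methylsulfonyl)-1,4-diazepan-1-yl gives a 5.7-fold higher number from compound 2 to compound 4 (0.75 log units; beyond the scatter) in the same direction. Nothing available explains these shifts. On these data alone, whether an ethyl group on the same sulfur would behave like methyl or like isopropyl remains open, as does the outcome with a trifluoromethyl group there.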